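The source may hold more compounds than are shown below. What is called first, only, known or untested is meant among the compounds shown, and "the series" means these compounds.

Compound 1 `N#Cc1ccc(Nc2nccc(Nc3ccc4cc(C#N)ccc4c3F)n2)cc1` gives 45000 nM in an ADME assay on MT2 cells (Homo sapiens) for inhibition, read by MTT assay; a higher number here means that more compound is tolerated, a lower number that less compound is tolerated. Compound 2 `N#Cc1ccc(Nc2nccc(Nc3ccc4cc(C#N)ccc4c3)n2)cc1` reaches only a limit in this assay, > 100000 nM. That limit is the limit of > 100000 nM in this assay, at which 1 of the 2 values shown sits, so compound 2 stands at the top of what the numbers show, without an exact figure. Compound 3 `Cc1c(Nc2ccnc(Nc3ccc(C#N)cc3)n2)ccc2cc(C#N)ccc12` differs from compound 2 by methyl in place of hydrogen on an aromatic carbon. Within the data shown here, the one measured step, an at least 2.2-fold higher number from compound 1 to compound 2 (0.34 log units; beyond the scatter), concerns the same place and shows that removing a small group there raised the tolerated amount. A methyl at that place may act the other way, so for compound 3 a modest fall in this assay is expected, an at least 1.8-fold lower number from compound 2 to compound 3 (0.25 log units; that floor lies within the scatter). Compound 3 is therefore estimated at 55000 nM, within 20000 nM to 120000 nM.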

Compound 3, half-maximal cytotoxic concentration: > 100000 nM
Compound 3: no number, only a limit; the forecaster's own chance of this, stated with the estimate: 40%; middle value at least 1.8-fold (0.25 log units) from the limit.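

Putting methyl in place of fluoro on this aromatic carbon gives an at least 2.2-fold higher number from compound 1 to compound 3 (0.34 log units; beyond the scatter) in this assay. So the methyl does not bring the lower number seen with fluoro, and compound 1 remains the only one of the three with an exact value. Compound 3 ends at a limit just as compound 2 does, so the step between them cannot be read: the limit of > 100000 nM in this assay, at which 2 of the 3 values shown sit.

On these data alone, how far compound 2 and compound 3 lie beyond that limit stays open. So does whether an amine or a longer chain at this position would give a lower number, as fluoro does.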